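Series notes: cyano in place of nitro toward compound 4

The source may report more compounds than this note shows. Statements on the series, on what has been measured and on what is new or still open speak of the compounds shown alone.

Measured compounds:
Compound 1 `N#Cc1ccc(Cn2cc(COc3ccc4c(=O)ccoc4c3)nn2)cc1` — > 100000 nM, a limit of the assay.
Compound 2 `O=c1ccoc2cc(OCc3cn(Cc4ccccc4)nn3)ccc12` — > 100000 nM, a limit of the assay.
Compound 3 `O=c1ccoc2cc(OCc3cn(Cc4cccc([N+](=O)[O-])c4)nn3)ccc12` — > 100000 nM, a limit of the assay.

In a functional assay on SGC-7901 cells (Homo sapiens) for cytotoxicity, read by MTT assay, with a stated time of 48 h (on this read-out lower numbers stand for stronger inhibition and higher numbers for weaker inhibition), compound 3 stands at a limit, as noted in the limit of > 100000 nM in this assay, at which 3 of the 3 values shown sit. The steps into it, a step that the two limits leave unreadable from compound 1 to compound 3 and a step that the two limits leave unreadable from compound 2 to compound 3, are therefore of unreadable size, and a step that the two limits leave unreadable from compound 1 to compound 2 is likewise unreadable. Compound 4 `N#Cc1cccc(Cn2cc(COc3ccc4c(=O)ccoc4c3)nn2)c1` differs from compound 3 by cyano in place of nitro on an aromatic carbon. Among the measured compounds shown here, no measured step shows any readable effect of swapping groups on this aromatic carbon, so no change beyond the scatter is expected, and compound 4 is estimated to remain at the limit, a step of a number no higher from compound 3 to compound 4 (the limit leaves the size open). For compound 4 the expected value is 100000 nM, between 50000 nM and 300000 nM.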

Compound 4, half-maximal inhibitory concentration: > 100000 nM
Compound 4 gave a limit, no number (the forecaster's own chance of this, stated with the estimate: 85%); the middle value sits exactly at the limit.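

In this assay, among the compounds shown here, compound 1, compound 2, compound 3 and compound 4 all stand at a limit, so no step among them can be read. Still open, from the compounds shown here alone, is whether any group on this aromatic ring would give a measurable number.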